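The compounds below may be only part of what the source reports. "The series", "measured", "known", "first", "only" and "open" are said of these compounds alone.

In a functional assay on A549 cells (Homo sapiens), read by MTT assay, with a stated time of 72 h (a lower number here means a stronger inhibitor, a higher number a weaker inhibitor), compound 2 `COc1ncnc2c1c(I)cn2[C@@H]1O[C@H](CO)[C@@H](O)[C@H]1O` gives only a limit, > 20000 nM. Compound 1 `COc1nc(N)nc2c1c(-c1cc3ccccc3o1)cn2[C@@H]1O[C@H](CO)[C@@H](O)[C@H]1O` likewise gives only a limit in this assay, > 20000 nM. Compound 3 `Nc1nc2c(c(-c3ccccc3)cn2[C@@H]2O[C@H](CO)[C@@H](O)[C@H]2O)c(=O)[nH]1` also gives only a limit in this assay, > 100000 nM. Within the data shown here, compound 2 thus sits at the limit of > 20000 nM in this assay, at which 2 of the 3 values shown sit, as does compound 1, while compound 3 sits at the limit of > 100000 nM in this assay, at which 1 of the 3 values shown sits; no measured step between any two of the three is known. Compound 4 `COc1ncnc2c1c(-c1cccs1)cn2[C@@H]1O[C@H](CO)[C@@H](O)[C@H]1O` differs from compound 2 by thiophen-2-yl in place of iodo on an aromatic carbon. Compound 1, carrying an aromatic ring in place of iodo, gives only a limit, > 20000 nM, so no step beyond the scatter is expected and the estimated step is a step that the limit leaves unreadable from compound 2 to compound 4. Compound 4 is expected at 30000 nM, between 8000 nM and 100000 nM, and may again be only a limit.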

Compound 4, half-maximal inhibitory concentration: 4850 nM
Compound 4: middle estimate off by 6.2-fold (0.79 log units), on the high side; the whole stated range lies above it.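

In this assay, thiophen-2-yl in place of iodo on this aromatic carbon gives an at least 4.1-fold lower number from compound 2 to compound 4 (0.61 log units; beyond the scatter), so a change at this position can register in the read-out. Compound 4 is the first compound shown with a number rather than a limit, which gives further changes here a readable starting point. The size of the step is only a bound, as compound 2 gives only a limit.

As far as these compounds go, it remains open whether the step is specific to thiophen-2-yl or extends to other five-membered aromatic rings. From the compounds shown here alone, how an amine or a carboxylic acid on this carbon would read is also open.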